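Opening a Three-Membered Ring on Two Related Cores

The compounds below may be only part of what the source reports. "The series", "measured", "known", "first", "only" and "open" are said of these compounds alone.

Four compounds share one set of atoms arranged into two cores. Compound 1 `COc1ccc(/C=C/C(=O)c2ccc(OCC3CO3)cc2)cc1` and compound 2 `COc1ccc(C(=O)/C=C/c2ccc(OCC3CO3)cc2)cc1` contain the same atoms joined differently; the difference between the two cores is not broken down here. Compound 3 `COc1ccc(C(=O)/C=C/c2ccc(OCC(O)CCl)cc2)cc1` arises from compound 2 by a single change: 2-chloro-1-hydroxyethyl in place of oxiran-2-yl on a saturated chain carbon bound to an oxygen on an aromatic ring. Compound 4 `COc1ccc(/C=C/C(=O)c2ccc(OCC(O)CCl)cc2)cc1`, not yet measured, arises from compound 1 by 2-chloro-1-hydroxyethyl in place of oxiran-2-yl on a saturated chain carbon bound to an oxygen on an aromatic ring. The place of the change is described in the same words for both pairs. It is the same change carried out on two cores.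

In an assay on isolated protein for inhibition of DNA topoisomerase 1 (Homo sapiens), tested at 100 uM (on this read-out lower numbers stand for less inhibition and higher numbers for more inhibition at the one concentration tested (going by the name of the read-out)), compound 1 gives 0%. Compound 2 gives 0%, and compound 3 gives 0%. Among the compounds with values here, the one measured step, no change at the digits printed from compound 2 to compound 3 (within the scatter), shows that opening the three-membered ring left the read-out where it was on the core of compound 2. Compound 1 stands level with compound 2 and compound 3, all within the usual scatter.

The step from compound 1 to compound 4 is expected to be no change at the digits printed from compound 1 to compound 4 (within the scatter). This expectation rests on the fact that no change at the digits printed from compound 2 to compound 3 (within the scatter) and on compound 1 starting from 0%. For compound 4 the estimated value is 0%, with an expected range from 0% to 10%. Only these two pairs are known, so nothing wider than this is claimed.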

Compound 4, a percentage reported as inhibition, at one concentration (the size of the read-out at that concentration, not a potency): 0%
For compound 4 middle estimate and measured number coincide at the digits printed; low and high end bracket the measured number.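

Replacing oxiran-2-yl with 2-chloro-1-hydroxyethyl on the core of compound 1 gives no change at the digits printed from compound 1 to compound 4 (within the scatter), and in this assay the result matches the one seen on the other core: the same change on two cores in this assay, no change at the digits printed (within the scatter) from compound 2 to compound 3 and no change at the digits printed (within the scatter) from compound 1 to compound 4, 0 percentage points apart, within the scatter of two such steps

So, for these two pairs, the change carries from one core to the other with the same outcome, and opening the three-membered ring gives no measurable inhibition on either core at the one concentration tested. This agreement is weak evidence, however, as all four compounds give the same reading of no inhibition, so both steps start and end at the bottom of the read-out, where a change that lowers inhibition could not show itself and the two cores cannot be told apart by how they respond.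

The compounds shown leave open whether an amine or a carboxylic acid in place of these groups, or a longer chain on the oxygen on the aromatic ring, would produce any inhibition in this assay. They also leave open whether swapping oxiran-2-yl for 2-chloro-1-hydroxyethyl would still leave the read-out unchanged on a related compound that already shows clear inhibition.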